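Amide variation on the shared core: removal of fluorine

The source may hold more compounds than are shown below. What is called first, only, known or untested is meant among the compounds shown, and "the series" means these compounds.

Measured compounds in a toxicity assay on THP-1 cells (Homo sapiens) for inhibition; on this read-out lower numbers stand for higher toxicity in this test and higher numbers for lower toxicity in this test:
compound 1, `COc1ccc(-c2cnc(NC(=O)C3CCCCC3)n2C)cc1`, at a limit of > 100000 nM
compound 2, `COc1ccc(-c2cnc(NC(=O)c3ccccn3)n2C)cc1`, at a limit of > 100000 nM
compound 3, `COc1ccc(-c2cnc(NC(=O)c3ccc(F)cc3)n2C)cc1`, at a limit of >= 50000 nM

None of the three amides on the shared core has given a number in this assay. Compound 3, with 4-fluorophenyl on the carbonyl carbon, stands at a limit, and the two other values shown are limits as well. The three steps among them, a step that the two limits leave unreadable from compound 1 to compound 2, a step that the two limits leave unreadable from compound 1 to compound 3 and a step that the two limits leave unreadable from compound 2 to compound 3, therefore cannot be sized. The evidence is confined to the limit of > 100000 nM in this assay, at which 2 of the 3 values shown sit, and (the limit of >= 50000 nM in this assay, at which 1 of the 3 values shown sits).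

Compound 4, `COc1ccc(-c2cnc(NC(=O)c3ccccc3)n2C)cc1`, differs from compound 3 by hydrogen in place of fluoro on an aromatic carbon. Among the measured compounds shown here, no measured step bears on this change; the amide swaps that are available were all unreadable, and they move a whole ring rather than a single substituent. With compound 3 at a limit and nothing to suggest a large shift, compound 4 is expected to sit near the same region, and the estimated step that the limit leaves unreadable from compound 3 to compound 4 is taken as none beyond the scatter. The estimate for compound 4 in this assay is 100000 nM, with a range from 50000 nM to 300000 nM, most likely reported again as a limit.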

Compound 4, half-maximal cytotoxic concentration: > 100000 nM
Compound 4 ended at the assay's limit (the forecaster's own chance of this, stated with the estimate: 85%); the middle value lies on the limit itself.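

In this assay compound 4 gives > 100000 nM, which is a limit of the assay. The steps to compound 4 from compound 1, compound 2 and compound 3 cannot be read. Still open, as far as these compounds go, is whether any amide on the shared core gives a number in this assay, and what size the change from 4-fluorophenyl to phenyl has.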